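Swapping the pyridinyl arm of compound 1 for a thiophenyl

The source may hold more compounds than are shown below. What is called first, only, known or untested is meant among the compounds shown, and "the series" means these compounds.

The account centres on compound 1, whose structure is `Oc1ccc(-c2cc(-c3cccc(Cl)c3)nc(-c3ccccn3)c2)cc1`. In an assay on isolated protein for inhibition of DNA topoisomerase 1 (Homo sapiens), with a stated time of 30 min, tested at 100 uM (a higher number here means a stronger effect of the compound at the concentration tested, a lower number a weaker effect), compound 1 gives 59.4%, the highest of the three numbers available. Compound 2, `Oc1cccc(-c2cc(-c3ccc(Cl)cc3)nc(-c3cccs3)c2)c1`, gives 15.1% in this assay, a number that lies far enough below compound 1 to sit beyond the usual scatter. Compound 3, `Oc1cccc(-c2cc(-c3ccncc3)nc(-c3ccccc3Cl)c2)c1`, gives 0% in this assay, the lowest number of the set and also beyond the scatter from compound 1. No two of these three compounds differ in a single place, so none of the gaps between them can be tied to one structural change.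

Compound 4, `Oc1ccc(-c2cc(-c3ccsc3)nc(-c3cccc(Cl)c3)c2)cc1`, has not yet been measured. It differs from compound 1 in one place: thiophen-3-yl in place of pyridin-2-yl on an aromatic carbon. Among the measured compounds shown here, the pair of compound 2 and compound 3, each carrying a different five- or six-membered aromatic arm at that position within otherwise different scaffolds, shows only that the compounds that lack a pyridin-2-yl arm have lower numbers, without isolating the cause.

Given that, a downward step beyond the scatter is expected for compound 4, estimated as a number 24.4 percentage points lower from compound 1 to compound 4 (beyond the scatter). Compound 4 is therefore estimated to give 35% in this assay, within a range from 10% to 60%.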

Compound 4, a percentage reported as inhibition, at one concentration (the size of the read-out at that concentration, not a potency): 26%
Compound 4: middle estimate off by 9 percentage points, on the high side; the measured number falls inside the stated range.
By their numbers in this assay, from the lowest: compound 3; then compound 2; then compound 4; then compound 1.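

In this assay, among the compounds shown here, thiophen-3-yl in place of pyridin-2-yl on the aromatic carbon next to the ring nitrogen gives a number 33.4 percentage points lower from compound 1 to compound 4 (beyond the scatter), and this is the first gap in the set that can be tied to one structural change, with the 3-chlorophenyl and 4-hydroxyphenyl groups and the shared core left as they are. The position therefore responds to this exchange, even though the two arms have the same printed counts of hydrogen-bond donors and acceptors and neither carries a net charge, so those counts do not separate them. Nothing available explains the drop, and no measurement bears on what the change does at this position.

With a single step, the compounds shown cannot tell whether the difference follows the ring size, the loss of the ring nitrogen or the arrival of the sulfur, and a phenyl or a pyridin-3-yl arm on this carbon would be needed to pull these apart. From the compounds shown here alone, it also remains open whether the same exchange would give a step of similar size with the chlorine or hydroxyl group placed elsewhere on the flanking phenyl rings.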